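This account rests on a few compounds, and the source may have more. Where it says the series, first, only, none or still open, it means among the compounds named here.

Of the compounds shown here, three of a shared core have been measured in an assay on CHO cells for antagonist activity at transient receptor potential cation channel subfamily V member 1 (Homo sapiens), read by FLIPR; on this read-out higher numbers stand for weaker inhibition and lower numbers for stronger inhibition. Compound 1 `CC(C(=O)NCc1ccc(C(F)(F)F)cc1N1CCCCCC1)c1ccc(NS(C)(=O)=O)c(F)c1` gives 1.6 nM, compound 2 `CC(C(=O)NCc1ccc(C(F)(F)F)cc1N1CCC(C(F)(F)F)CC1)c1ccc(NS(C)(=O)=O)c(F)c1` gives 0.4 nM, and compound 3 `CCCCSc1cc(C(F)(F)F)ccc1CNC(=O)C(C)c1ccc(NS(C)(=O)=O)c(F)c1` gives 1.9 nM. Compound 3 holds the highest of the three numbers, though its gap to compound 1 is within the scatter, as the step of a 1.2-fold higher number from compound 1 to compound 3 (0.07 log units; within the scatter) shows, while the step of a 4.8-fold higher number from compound 2 to compound 3 (0.68 log units; beyond the scatter) lies beyond it. The substituent on the aromatic carbon is the only thing that varies across these three, and the step of a 4.0-fold lower number from compound 1 to compound 2 (0.60 log units; beyond the scatter) shows that a change there can move the number by a modest amount.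

Compound 4 `CC(C(=O)NCc1ccc(C(F)(F)F)cc1-c1cccc(Cl)c1)c1ccc(NS(C)(=O)=O)c(F)c1` carries a further change at the same place: 3-chlorophenyl in place of butylsulfanyl on an aromatic carbon. Within the data shown here, no measured step involves a 3-chlorophenyl group or any aromatic ring at this position, so the steps seen so far bear on it only by showing how much this position has moved the number: all three measured compounds lie within a modest range in this assay. An aromatic ring departs from the chains and saturated rings seen, so the direction is open. A step of size a 1.3-fold lower number from compound 3 to compound 4 (0.10 log units; within the scatter) is therefore expected, within the scatter in either direction. Compound 4 is estimated to give 1.5 nM, with a range from 0.4 nM to 6 nM.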

Compound 4, inhibition constant: 1 nM
The estimate for compound 4 lay 1.5-fold (0.18 log units) above the measured number; the measured number falls inside the stated range.
By their numbers in this assay, from the lowest: compound 2; then compounds 4, 1 and 3 (each within the scatter of the next).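

The 3-chlorophenyl group shows that a six-membered aromatic ring of carbon only can stand at this position, ortho to a large group, without leaving the range set by the chain and the saturated ring in this assay: the change from butylsulfanyl (a 1.9-fold lower number from compound 3 to compound 4 (0.28 log units; within the scatter)) and the change from azepan-1-yl (a 1.6-fold lower number from compound 1 to compound 4 (0.20 log units; within the scatter)) both lie within the scatter, so compounds 1, 3 and 4 cannot be told apart here. Among these compounds, replacing the 4-(trifluoromethyl)piperidin-1-yl group with 3-chlorophenyl is the one new step that leaves the scatter (a 2.5-fold higher number from compound 2 to compound 4 (0.40 log units; beyond the scatter)), so compound 2 still gives the lowest number of the four, and the aromatic ring adds a third kind of group that does not reach it.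

As far as these compounds go, what the chlorine itself contributes remains open, and a plain phenyl group at this position would separate it from the ring. A pyridine ring or a carboxylic acid on the ring would show whether this position also accepts groups of a different kind.

Nothing among the data given accounts for any of these steps.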